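Bromo in Place of Hydrogen: From Compound 3 to Compound 4

The compounds below may be only part of what the source reports. "The series", "measured", "known", "first", "only" and "open" are said of these compounds alone.

Three compounds share one core and were measured in an assay on isolated protein for inhibition of Amine oxidase [flavin-containing] B (Homo sapiens), read by fluorescence and Amplex Red, with stated times of 15 min and 20 min; on this read-out higher numbers stand for weaker inhibition and lower numbers for stronger inhibition. Compound 1 `Cc1cccc(/C=N/c2ccc(OCc3ccccc3)cc2)c1O` gives 15500 nM, compound 2 `Oc1ccc(/C=N/c2ccc(OCc3ccccc3)cc2)c(O)c1` gives 6780 nM, and compound 3 `Oc1ccccc1/C=N/c1ccc(OCc2ccccc2)cc1` gives 25100 nM. Compound 3 stands highest of the three numbers; its nearest neighbour is compound 1 (a 1.6-fold higher number from compound 1 to compound 3 (0.21 log units; within the scatter)), and its furthest is compound 2 (a 3.7-fold higher number from compound 2 to compound 3 (0.57 log units; beyond the scatter)).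

Compound 4 `Oc1ccc(Br)cc1/C=N/c1ccc(OCc2ccccc2)cc1` differs from compound 3 in one place: bromo in place of hydrogen on an aromatic carbon. Going by the values given here, no measured step tests a bromo group. The closest comparison is the methyl-to-hydrogen step, a 1.6-fold higher number from compound 1 to compound 3 (0.21 log units; within the scatter), which stayed within the scatter, while the hydroxy-to-hydrogen step, a 3.7-fold higher number from compound 2 to compound 3 (0.57 log units; beyond the scatter), was modest. The account therefore expects a small step for this assay , if any, and no step beyond the scatter is expected: a 1.7-fold lower number from compound 3 to compound 4 (0.22 log units; within the scatter). Compound 4 is estimated at 15000 nM, within a range from 5000 nM to 45000 nM.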

Compound 4, half-maximal inhibitory concentration: 31700 nM
For compound 4 the middle estimate is 2.1-fold (0.32 log units) below the measured one, within the range that was stated.
By their numbers in this assay, from the lowest: compound 2; then compounds 1, 3 and 4 (each within the scatter of the next, the first and the last beyond it).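

In this assay, bromo on this aromatic carbon, para to a hydroxy group, brings no change beyond the scatter, a 1.3-fold higher number from compound 3 to compound 4 (0.10 log units; within the scatter), so this position accepts a bromine atom without a clear gain or loss from the unsubstituted 2-hydroxyphenyl compound. Against the other substituted rings, the 5-bromo-2-hydroxyphenyl group gives steps beyond the scatter, both modest: a 4.7-fold higher number from compound 2 to compound 4 (0.67 log units; beyond the scatter) and a 2.0-fold higher number from compound 1 to compound 4 (0.31 log units; beyond the scatter). No measurement at hand accounts for these results.

The compounds shown leave open whether a chlorine atom, a methoxy group or an amine at this same carbon would also stay within the scatter of compound 3. They also leave open how bromo would read on the 2,4-dihydroxyphenyl ring of compound 2.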